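The compounds below may be only part of what the source reports. "The series", "measured", "known", "first", "only" and "open" are said of these compounds alone.

Working notes on the piperidinyl urea series, following the step from compound 3 to compound 4.

Compound 3 `CC[C@H](C)C(=O)N1CCC(NC(=O)Nc2ccc(C(F)(F)F)c(F)c2)CC1` sits lowest of the three numbers in a physicochemical assay for solubility, read by mass spectrometry, in phosphate buffer, with a stated time of 24 h, at pH 7.4; on this read-out lower numbers stand for lower solubility and higher numbers for higher solubility: compound 3 gives 0.46 ug/mL. Among the measured compounds shown here, the nearest measured compound is compound 1 `CCC(=O)N1CCC(NC(=O)Nc2ccc(C(F)(F)F)c(F)c2)CC1`, which in this assay gives 3.9 ug/mL; the single one-place step in hand, an 8.5-fold lower number from compound 1 to compound 3 (0.93 log units; beyond the scatter), shows that growing the chain on the saturated carbon bound to the carbonyl pulls the number down. For the measured compounds named here, compound 2 `O=C(Nc1ccc(OC(F)(F)F)c(F)c1)NC1CCN(C(=O)C2CCCOC2)CC1`, which carries the oxan-3-yl carbonyl together with a trifluoromethoxy group on the aryl ring, gives 174 ug/mL in this assay; no single-place step links compound 2 to compound 3, so its value can only be read as an indication.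

Compound 4 `O=C(Nc1ccc(C(F)(F)F)c(F)c1)NC1CCN(C(=O)C2CCCOC2)CC1` differs from compound 3 by oxan-3-yl in place of sec-butyl on a carbonyl carbon. The step from compound 1 to compound 3 ran in the direction of a smaller number when the chain was enlarged; reversing toward a ring bearing an oxygen, as in compound 2, points the other way. Compound 4 is therefore expected to move upward in this assay, by about a 33-fold higher number from compound 3 to compound 4 (1.51 log units; beyond the scatter), though with wide uncertainty since compound 2 also carries a different aryl substituent. The estimate for compound 4 is 15 ug/mL, within a range of 3 ug/mL to 80 ug/mL.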

Compound 4, solubility: 11 ug/mL
The estimate for compound 4 lay 1.4-fold (0.13 log units) above the measured number; the measured number falls inside the stated range.
By their numbers in this assay, from the lowest: compound 3; then compound 1; then compound 4; then compound 2.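

At the carbonyl carbon, oxan-3-yl now has a direct reading in this assay: a 24-fold higher number from compound 3 to compound 4 (1.38 log units; beyond the scatter) with oxan-3-yl in place of sec-butyl, and a 2.8-fold higher number from compound 1 to compound 4 (0.45 log units; beyond the scatter) with oxan-3-yl in place of ethyl. With oxan-3-yl held constant, the aryl substituent also proves to matter, as trifluoromethyl in place of trifluoromethoxy on the aromatic carbon gives a 16-fold lower number from compound 2 to compound 4 (1.20 log units; beyond the scatter); the high number of compound 2 therefore does not follow from oxan-3-yl alone. The data in hand offer no measurement that accounts for any of these moves.

As far as these compounds go, it remains open how an amine or a carboxylic acid in place of oxan-3-yl on the carbonyl carbon would read in this assay. Also open, from the compounds shown here alone, is whether trifluoromethoxy in place of trifluoromethyl would move the number in the same direction with ethyl or sec-butyl on the carbonyl carbon.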